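The compounds below may be only part of what the source reports. "The series", "measured", "known", "first", "only" and "open" are said of these compounds alone.

Measured compounds, with their results in an assay on adrenal cortex for inhibition of angiotensinogen (Rattus norvegicus); a lower number here means a stronger inhibitor, a higher number a weaker inhibitor:
compound 1 `CCCCC1Nc2ccccc2C(=O)N1Cc1ccc(-c2ccccc2-c2nn[nH]n2)cc1`: 14000 nM
compound 2 `CCCCC1Nc2ccc(C(C)C)cc2C(=O)N1Cc1ccc(-c2ccccc2-c2nn[nH]n2)cc1`: 1100 nM
compound 3 `CCC1Nc2ccccc2C(=O)N1Cc1ccc(-c2ccccc2-c2nn[nH]n2)cc1`: 45000 nM

Compound 1 stands second highest of the three numbers in this assay. Its nearest neighbour is compound 3, reached by a 3.2-fold higher number from compound 1 to compound 3 (0.51 log units; beyond the scatter). Its furthest is compound 2, reached by a 13-fold lower number from compound 1 to compound 2 (1.10 log units; beyond the scatter).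

Compound 4 `CCCCC1N(Cc2ccc(-c3ccccc3-c3nn[nH]n3)cc2)C(=O)c2ccccc2N1C` is not yet measured. It differs from compound 1 by methyl in place of hydrogen on a nitrogen on an aromatic ring in a ring.

Neither measured step bears directly on this change. The step from compound 1 to compound 2 concerns a substituent on an aromatic carbon, and the step from compound 1 to compound 3 concerns the length of the chain on a saturated ring carbon; both leave the ring nitrogen untouched. Nothing measured here therefore tells what the methyl on that nitrogen does. In the absence of such a step, compound 4 is expected to stay near compound 1, with the step of a 1.1-fold higher number from compound 1 to compound 4 (0.03 log units; within the scatter) estimated as lying within or close to the scatter. The estimate for compound 4 in this assay is 15000 nM, with a range from 4000 nM to 60000 nM.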

Compound 4, half-maximal inhibitory concentration: 14000 nM
Beside the measured number, compound 4's estimate is 1.1-fold (0.03 log units) above it; the measured number falls inside the stated range.
By their numbers in this assay, from the lowest: compound 2; then compounds 1 and 4 (each within the scatter of the next); then compound 3.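

In this assay methyl in place of hydrogen on the nitrogen on an aromatic ring gives no change at the digits printed from compound 1 to compound 4 (within the scatter) and so shows that this position accepts one added carbon without a readable shift. Among the compounds shown here, the earlier compounds all carry hydrogen on this nitrogen, so only this step shows that the hydrogen can be replaced, even with the butyl group on the neighbouring ring atom, and that the number of compound 1 holds without it. No measurement at hand explains this result.

The compounds shown leave open whether a longer chain such as ethyl or propyl, or an acetyl group, on this nitrogen would read the same way. They also leave open whether methyl here would act alike with the isopropyl group of compound 2 or the shorter chain of compound 3.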